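Swapping the piperazinone tail for a dihydroxypropyl piperazine

This account rests on a few compounds, and the source may have more. Where it says the series, first, only, none or still open, it means among the compounds named here.

Among the measured compounds shown here, compound 2 `CCc1nn2c(C)cc(C)nc2c1Cc1ccc(/C=C/CN2CCNC(=O)C2)cc1` is one of two compounds so far tested in a functional assay on HeLa cells for antagonist activity at G-prodeshotein coupled receptor 4 (Homo sapiens), read by HTRF and cAMP accumulation, with a stated time of 15 min (on this read-out higher numbers stand for weaker inhibition and lower numbers for stronger inhibition), where compound 2 gives 27 nM. For the measured compounds named here, on these numbers compound 2 stands highest, yet its only neighbour, compound 1 `CCc1nn2c(C)cc(C)nc2c1Cc1ccc(CCC(O)C2CCNCC2)cc1`, gives 24 nM in this assay, and the step of a 1.1-fold higher number from compound 1 to compound 2 (0.05 log units; within the scatter) is within the scatter, so the two cannot be told apart.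

Compound 3 `CCc1nn2c(C)cc(C)nc2c1Cc1ccc(/C=C/CN2CCN(C[C@@H](O)CO)CC2)cc1` has not been measured yet. It differs from compound 2 in one place: 4-(2,3-dihydroxypropyl)piperazin-1-yl in place of 3-oxopiperazin-1-yl on a saturated chain carbon bound to a double-bonded chain carbon. Going by the values given here, the only measured step that bears on this is a 1.1-fold higher number from compound 1 to compound 2 (0.05 log units; within the scatter): there the whole tail was exchanged, and the number barely moved. Because the step of a 1.1-fold higher number from compound 1 to compound 2 (0.05 log units; within the scatter) stayed within the scatter after a much larger rebuild of the tail, compound 3 is expected to sit close to compound 2 in this assay, with no step beyond the scatter in either direction. The estimated value for compound 3 is 30 nM, with a range from 10 nM to 90 nM. This estimate means an expected step of a 1.1-fold higher number from compound 2 to compound 3 (0.05 log units; within the scatter).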

Compound 3, half-maximal inhibitory concentration: 21 nM
The estimate for compound 3 lay 1.4-fold (0.15 log units) above the measured number, and the stated range covers the measured number.
By their numbers in this assay, from the lowest: compounds 3, 1 and 2 (each within the scatter of the next).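

On the saturated chain carbon bound to a double-bonded chain carbon, the 3-oxopiperazin-1-yl group can be replaced by the larger 4-(2,3-dihydroxypropyl)piperazin-1-yl group, with a 1.3-fold lower number from compound 2 to compound 3 (0.11 log units; within the scatter) in this assay, so compound 2 and compound 3 cannot be told apart. The earlier pair exchanged the whole tail, chain included, whereas this pair keeps the chain and alters only the ring unit at its end, so the effect of that one change can be read on its own: the position accepts more heavy atoms, more hydrogen-bond donors and acceptors and a defined stereocentre with no readable difference in this read-out. Nothing available explains why the number holds across this change.

The compounds shown leave open how much of the 2,3-dihydroxypropyl arm is needed, since neither a plain 4-methylpiperazin-1-yl group nor a carboxylic acid at the end of a longer chain is among them. They also leave open whether the mirror-image form of the arm, with the opposite arrangement at its stereocentre, would give a similar number.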